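The compounds below may be only part of what the source reports. "The series", "measured", "known", "first", "only" and "open" are said of these compounds alone.

In a functional assay on A549 cells (Homo sapiens) for antiproliferative activity, read by sulforhodamine B assay, with a stated time of 48 h (a higher number here means a weaker inhibitor, a lower number a stronger inhibitor), compound 1 `COc1cc(/C=C/C(=O)c2ccccc2-c2ccc(F)cc2)ccc1O` gives 7600 nM, a measured number that serves as a reference point. Compound 2 `COc1ccc(C(=O)/C=C/c2ccccc2-c2ccc(F)nc2)cc1` reads > 50000 nM, which is a limit of the assay and not a number. Compound 2 therefore offers no exact starting value, and any comparison with it has to begin from that limit.

Compound 3 `COc1ccc(C(=O)/C=C/c2ccccc2-c2ccc(F)nc2)cc1OC` is built from compound 2 by one change: methoxy in place of hydrogen on an aromatic carbon. The new group sits ortho to a methoxy group and meta to a large group, and the count of the change is methoxy in place of hydrogen on an aromatic carbon.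

Among the compounds with values here, no measured pair here shows what a single change of this kind does, so the expectation rests on little. A small move toward stronger inhibition in this assay seems most likely, with no change beyond the scatter also quite possible, and another reading at the limit would not surprise. The estimated step is an at least 1.4-fold lower number from compound 2 to compound 3 (0.15 log units; that floor lies within the scatter). For compound 3 the expected value is 35000 nM, with an estimated range from 14000 nM to 90000 nM.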

Compound 3, half-maximal inhibitory concentration: 17000 nM
For compound 3 the middle estimate is 2.1-fold (0.31 log units) above the measured one, and the stated range covers the measured number.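

In this assay, putting methoxy in place of hydrogen on this aromatic carbon, ortho to a methoxy group and meta to a large group, gives an at least 2.9-fold lower number from compound 2 to compound 3 (0.46 log units; beyond the scatter). Within the data shown here, this is the first single change that can be read in this small set, and it shows that the added methoxy at this position moves the number toward stronger inhibition and brings compound 3 off the limit of the assay, to a measured value. The step is only a floor, and its true size remains unknown, because compound 2 has a limit and not a number as its starting point: the limit of > 50000 nM in this assay, at which 1 of the 3 values shown sits.

From the compounds shown here alone, whether another group on the same aromatic carbon, such as ethoxy, an amine or a chlorine atom, would give a similar step remains open, as does whether methoxy would do so on a different carbon of this ring. A single step also cannot show whether this change would act alike on another core, such as that of compound 1, which differs from compound 3 in more than one place.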